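The compounds below may be only part of what the source reports. "The series", "measured", "known", "first", "only" and "open" are said of these compounds alone.

Compound 3 `CC(C)(C)c1ccc(-c2cc(N3CCC(CCNS(N)(=O)=O)CC3)ncn2)cc1` gives 10300 nM in a functional assay on HT-29 cells (Homo sapiens) for antiproliferative activity, read by sulforhodamine B assay, with a stated time of 48 h (on this read-out lower numbers stand for stronger inhibition of growth and higher numbers for weaker inhibition of growth), the lowest of the three numbers in hand. Compound 1 `NS(=O)(=O)NCC1CCN(c2cc(-c3ccc(Cl)cc3)ncn2)CC1` gives 37700 nM in this assay, and compound 2 `NS(=O)(=O)NCCC1CCN(c2cc(-c3ccccc3)ncn2)CC1` gives 66500 nM. The gap between compound 3 and compound 1 lies beyond the scatter, as does the gap between compound 3 and compound 2.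

Compound 4 `NS(=O)(=O)NCCC1CCN(c2cc(-c3ccc(Cl)cc3)ncn2)CC1` differs from compound 3 in a single place: chloro in place of tert-butyl on an aromatic carbon. Among the compounds with values here, one measured step bears on this change, a 6.5-fold lower number from compound 2 to compound 3 (0.81 log units; beyond the scatter), which shows that the tert-butyl group is worth a modest but real improvement over hydrogen at this carbon. Within the data shown here, the chloro group has no step of its own; compound 1 carries a chloro at the same carbon but with a shorter chain to the sulfamide, and its value sits well above that of compound 3. Taking the chloro as standing somewhere between hydrogen and tert-butyl, the account expects the number to rise beyond the scatter on going to compound 4, by about a 2.9-fold higher number from compound 3 to compound 4 (0.46 log units; beyond the scatter). Compound 4 is therefore estimated at 30000 nM in this assay, with a likely range from 10000 nM to 90000 nM.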

Compound 4, concentration for 50% growth inhibition: 30500 nM
The estimate for compound 4 lay 1.0-fold (0.01 log units) below the measured number, and the stated range covers the measured number.
By their numbers in this assay, from the lowest: compound 3; then compounds 4, 1 and 2 (each within the scatter of the next, the first and the last beyond it).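

Chloro in place of hydrogen brings a 2.2-fold lower number from compound 2 to compound 4 (0.34 log units; beyond the scatter), while chloro in place of tert-butyl brings a 3.0-fold higher number from compound 3 to compound 4 (0.47 log units; beyond the scatter), so in this assay the group on this aromatic carbon matters with the chain held fixed, and the three compounds now separate hydrogen, chloro and tert-butyl, with tert-butyl giving the lowest number. Within the data shown here, the chain change, (sulfamoylamino)methyl in place of sulfamoylamino, can now be read for the first time, as a 1.2-fold lower number from compound 1 to compound 4 (0.09 log units; within the scatter), and with chloro on the aromatic carbon it cannot be told from the scatter. Nothing at hand accounts for why the numbers fall as they do.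

The compounds shown leave open whether the chain change would stay as small with hydrogen or tert-butyl on the aromatic carbon, and whether a still longer chain to the sulfamide would behave the same way. They also leave open how a methoxy group, a trifluoromethyl group or an amine at this carbon would compare with chloro and tert-butyl.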